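The source may report more compounds than this note shows. Statements on the series, on what has been measured and on what is new or still open speak of the compounds shown alone.

For the measured compounds named here, in a functional assay on LNCaP cells (Homo sapiens) for antiproliferative activity, read by propidium iodide staining, with a stated time of 96 h (on this read-out higher numbers stand for weaker inhibition and lower numbers for stronger inhibition), compound 1 (`CC(O)(COc1cccc(C(F)(F)F)c1)C(=O)Nc1cccc(S(F)(F)(F)(F)F)c1`) gives 28800 nM and compound 2 (`CC(O)(COc1cccc(OC(F)(F)F)c1)C(=O)Nc1cccc(S(F)(F)(F)(F)F)c1`) gives 15200 nM as its value, so compound 1 stands within the scatter of its only measured neighbour. Compound 3 (`CC(O)(COc1ccc(C#N)c(F)c1)C(=O)Nc1cccc(S(F)(F)(F)(F)F)c1`) has 4-cyano-3-fluorophenyl in place of 3-(trifluoromethyl)phenyl on an oxygen on a saturated carbon. Going by the values given here, the one measured step bearing on this (a 1.9-fold lower number from compound 1 to compound 2 (0.28 log units; within the scatter)) exchanges only trifluoromethoxy for trifluoromethyl and says nothing about a nitrile, so no change beyond the scatter is expected in this assay for this exchange. The expected step is small (a 1.4-fold lower number from compound 1 to compound 3 (0.16 log units; within the scatter)). For compound 3 the estimate is 20000 nM (expected range 7000 nM to 50000 nM).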

Compound 3, half-maximal inhibitory concentration: 83700 nM
Compound 3: middle estimate off by 4.2-fold (0.62 log units), on the low side; the measured number lies above the stated range.
By their numbers in this assay, from the lowest: compounds 2 and 1 (each within the scatter of the next); then compound 3.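

For the compounds shown here, replacing 3-(trifluoromethyl)phenyl with 4-cyano-3-fluorophenyl on the oxygen gives the first step beyond the scatter in this assay: a 2.9-fold higher number from compound 1 to compound 3 (0.46 log units; beyond the scatter). The direction is towards weaker inhibition, so this position does respond to the aryl group it carries, which the earlier pair, within the scatter of each other, did not show. No available evidence accounts for this step.

On these data alone, the exchange brings in the nitrile and changes the fluorine together, so their separate contributions remain open. Also open, as far as these compounds go, is how an amine or a carboxylic acid would behave in place of the nitrile.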